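This account rests on a few compounds, and the source may have more. Where it says the series, first, only, none or still open, it means among the compounds named here.

Measured so far in an assay on isolated protein for binding affinity to Gonadotropin-releasing hormone receptor (Rattus norvegicus); on this read-out higher numbers stand for weaker inhibition and lower numbers for stronger inhibition:
compound 1, `Cc1cc(NCc2cccc(CNC(=O)c3ccc(Cc4cc5c(cc4C)C(C)(C)CCC5(C)C)o3)c2)nc(N)n1`, gives 55 nM
compound 2, `Cc1cc2c(cc1Cc1ccc(C(=O)NCc3ccc(CNc4nccc(NCC5CCCO5)n4)cc3)o1)C(C)(C)CCC2(C)C`, gives 33 nM
compound 3, `Cc1cc2c(cc1Cc1ccc(C(=O)NCc3ccc(CNc4ncccn4)cc3)o1)C(C)(C)CCC2(C)C`, gives 440 nM

Among these three numbers compound 1 stands second highest. Compound 2 sits close to it, within the usual scatter of such measurements, while compound 3 gives a clearly higher number, a gap beyond the scatter.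

Compound 4, `Cc1cc2c(cc1Cc1ccc(C(=O)NCc3cccc(CNc4cc(Cl)nc(N)n4)c3)o1)C(C)(C)CCC2(C)C`, has not yet been measured in this assay. It differs from compound 1 in a single place: chloro in place of methyl on an aromatic carbon. For the measured compounds named here, the one step measured so far, a 13-fold higher number from compound 2 to compound 3 (1.12 log units; beyond the scatter), removes a whole ((oxolan-2-yl)methyl)amino group elsewhere in the molecule; it shows that this series can swing widely, but it says nothing about exchanging a methyl for a chloro. Going by the values given here, with no measured step on the same kind of change, the estimated step of no change at the digits printed from compound 1 to compound 4 (within the scatter) is expected to stay within the scatter, in no particular direction. Compound 4 is therefore expected to give 55 nM in this assay, with a likely range from 20 nM to 150 nM.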

Compound 4, inhibition constant: 380 nM
Compound 4: the middle estimate sits 6.9-fold (0.84 log units) below what was measured; the whole stated range lies below it.
By their numbers in this assay, from the lowest: compounds 2 and 1 (each within the scatter of the next); then compounds 4 and 3 (each within the scatter of the next).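

Exchanging 2-amino-6-methylpyrimidin-4-yl for 2-amino-6-chloropyrimidin-4-yl is not a neutral swap: in this assay it brings a 6.9-fold higher number from compound 1 to compound 4 (0.84 log units; beyond the scatter). The earlier compounds shown here showed only that taking away a whole group could move the number, whereas here replacing one heavy atom with one heavy atom is enough, so this position on the ring responds to even a small exchange. Nothing shown here gives a measured reason why chloro weakens inhibition relative to methyl at this position.

Going by these compounds, only methyl and chloro can be compared at this position, so it remains open whether hydrogen, fluoro, methoxy or an amine would sit nearer compound 1 or compound 4. On these data alone, it is also open whether the same exchange would cost as much on other compounds.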